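The compounds below may be only part of what the source reports. "The series", "measured", "known", "first", "only" and "open" are said of these compounds alone.

Compound 1 `CCCc1n[nH]c2c(=O)n(NC(=O)c3ccncc3)c(-c3cccc(OC)c3)nc12` is the starting point of this step. In a functional assay on SK-OV-3 cells (Homo sapiens) for cytotoxicity, read by sulforhodamine B assay, with a stated time of 2 days, tested at 100 uM (a higher number here means more inhibition at the concentration tested (going by the name of the read-out), a lower number less inhibition), compound 1 gives 4.04%. That is the lower of the two numbers measured in this assay: compound 2 `O=C(Nn1c(-c2cccc([N+](=O)[O-])c2)nc2c(-c3ccc(Cl)cc3)n[nH]c2c1=O)c1cccnc1` in this assay gives 30.2%, and the gap between compound 1 and compound 2 lies beyond the scatter of the method. Among the compounds with values here, compound 2 differs from compound 1 in more than one place, so those two values show only that one compound of this core sits near the bottom of the scale and another clearly higher.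

The new compound is compound 3 `COc1cccc(-c2nc3c(-c4ccc(Cl)cc4)n[nH]c3c(=O)n2NC(=O)c2ccncc2)c1`. Compound 3 differs from compound 1 in one place: 4-chlorophenyl in place of propyl on an aromatic carbon. Compound 3 therefore carries the same 4-chlorophenyl that compound 2 carries, while keeping the rest of compound 1.

Within the data shown here, with no measured one-place step to go by, the size of the change from compound 1 to compound 3 in this assay is uncertain. Compound 3 is expected to give 15%, within 2% to 35%. The expected step of a number 11 percentage points higher from compound 1 to compound 3 (beyond the scatter) is a modest rise, upward rather than downward, though one that may not clear the scatter.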

Compound 3, a percentage reported as inhibition, at one concentration (the size of the read-out at that concentration, not a potency): 42.5%
Estimate against measurement, compound 3: 27.5 percentage points below; the whole stated range lies below it.
By their numbers in this assay, from the lowest: compound 1; then compound 2; then compound 3.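

In this assay, within the data shown here, the change of 4-chlorophenyl in place of propyl on the aromatic carbon of the five-membered ring is the only step here that isolates one position, and it reads a number 38.5 percentage points higher from compound 1 to compound 3 (beyond the scatter). Compounds 1 and 2 differ in more than one place, so their gap could not be assigned to any single part of the structure, whereas this step shows that the group on this carbon alone can move the inhibition at the tested concentration by a large amount while the rest of compound 1 stays the same. The data give no measured basis for explaining the size of this step.

Going by these compounds, it remains open whether the rise follows from the aromatic ring, from the chlorine or simply from the larger group, a question that a plain phenyl, a 4-methoxyphenyl, a longer alkyl chain, an amine or a carboxylic acid on this carbon could help settle. On these data alone, it is also open whether the step would keep its size with other groups elsewhere on the core, and, as the read-out comes from a single concentration, what it means for potency.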